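This account rests on a few compounds, and the source may have more. Where it says the series, first, only, none or still open, it means among the compounds named here.

Working notes on the series. In a functional assay on CHO cells with metabotropic glutamate receptor 2 (Homo sapiens) as the target, read by GTPgammaS binding (on this read-out lower numbers stand for smaller maximal responses and higher numbers for larger maximal responses), compound 1 `Cc1cc(C)nc(N2CCN(c3ccn4c(CC(F)(F)F)cnc4c3C#N)CC2)n1` gives 128%, compound 2 `CCCc1cnc2c(C#N)c(N3CCN(c4ncccn4)CC3)ccn12` gives 248%, and compound 3 `CCc1cnc2c(C#N)c(N3CCN(c4ncccn4)CC3)ccn12` gives 214%. Compound 3 therefore stands second highest of the three numbers. Its nearest neighbour is compound 2, and compound 1 lies further from it; both gaps are beyond the scatter. Going by the values given here, the only measured step in this part of the structure is a number 34 percentage points lower from compound 2 to compound 3 (beyond the scatter), which is hydrogen in place of methyl on a saturated chain carbon, two bonds along the chain from an aromatic carbon.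

Compound 4 `N#Cc1c(N2CCN(c3ncccn3)CC2)ccn2c(CC(F)(F)F)cnc12` differs from compound 3 by trifluoromethyl in place of methyl on a saturated chain carbon bound to an aromatic carbon. Among the compounds with values here, no measured step carries exactly this change. Compound 1 also bears the 2,2,2-trifluoroethyl chain, but its other ring differs as well, so its value of 128% cannot be set against compound 3 alone. The step from compound 2 to compound 3 shows that a change on this chain can move the maximal response beyond the scatter, in either direction a priori. On that basis, relative to compound 3, compound 4 is expected to show in this assay a step of a number 19 percentage points lower from compound 3 to compound 4 (beyond the scatter). The estimated value for compound 4 is 195%, with a range from 130% to 260%.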

Compound 4, largest response reached (Emax), in percent of the reference or control that the assay uses: 231%
Compound 4: middle estimate off by 36 percentage points, on the low side, within the range that was stated.
By their numbers in this assay, from the lowest: compound 1; then compound 3; then compound 4; then compound 2.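

Trifluoromethyl in place of methyl on a saturated chain carbon bound to an aromatic carbon gives, in this assay, a number 17 percentage points higher from compound 3 to compound 4 (beyond the scatter), so the fluorinated chain does not reduce the maximal response relative to the ethyl chain, as the value of compound 1 alone might have suggested. A second comparison at the same place gives a number 17 percentage points lower from compound 2 to compound 4 (beyond the scatter), which leaves the 2,2,2-trifluoroethyl chain with a value inside the span set by the two non-fluorinated chains, with both modest steps beyond the scatter. With the 2,2,2-trifluoroethyl chain held constant, the change of pyrimidin-2-yl for 4,6-dimethylpyrimidin-2-yl on an amine nitrogen in a ring gives a number 103 percentage points higher from compound 1 to compound 4 (beyond the scatter), a large step that ties the gap between these two compounds to that ring substituent and not to the chain.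

Nothing measured here accounts for the size or direction of these steps. Still open, as far as these compounds go, is how a longer fluorinated chain, a hydroxyl or an amine would act at this place, and whether the 4,6-dimethylpyrimidin-2-yl step keeps its size with an ethyl chain.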